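Working notes: from compound 2 to compound 3

The source may report more compounds than this note shows. Statements on the series, on what has been measured and on what is new or still open speak of the compounds shown alone.

compound 1 `COC1=C(C)C(=O)/C(=C(O)/C=C/c2ccc(F)cc2)C(=O)C1(C)C` gives 4.1 ug/mL
compound 2 `COC1=C(C)C(=O)/C(=C(O)/C=C/c2ccccc2C)C(=O)C1(C)C` gives 5.2 ug/mL

In a functional assay on A-431 cells (Homo sapiens) for cytotoxicity (on this read-out lower numbers stand for an effect already at smaller amounts and higher numbers for an effect only at larger amounts of compound), compound 2 at 5.2 ug/mL lies within the scatter of compound 1. Among the compounds with values here, the only measured step is a 1.3-fold higher number from compound 1 to compound 2 (0.10 log units; within the scatter) and it exchanges one substituted phenyl for another. Compound 3 `COC1=C(C)C(=O)/C(=C(O)/C=C/c2cccs2)C(=O)C1(C)C` carries thiophen-2-yl in place of 2-methylphenyl on a double-bonded chain carbon bound to a double-bonded chain carbon, and the change is thiophen-2-yl in place of 2-methylphenyl on a double-bonded chain carbon bound to a double-bonded chain carbon at that place. Within the data shown here, no measured compound holds this ring, so that step is only a loose guide, and no shift beyond the scatter is expected. The estimated move in this assay is a 1.1-fold lower number from compound 2 to compound 3 (0.03 log units; within the scatter) and so stays inside the scatter. For compound 3 the estimated value is 4.8 ug/mL with an expected range from 2.2 ug/mL to 10 ug/mL in this series.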

Compound 3, concentration for half-maximal effect: 10.8 ug/mL
For compound 3 the middle estimate is 2.3-fold (0.35 log units) below the measured one; measured number outside the range, above it.
By their numbers in this assay, from the lowest: compounds 1 and 2 (each within the scatter of the next); then compound 3.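

In this assay this position, on a double-bonded chain carbon bound to a double-bonded chain carbon, does respond to the ring it carries: thiophen-2-yl gives a 2.1-fold higher number from compound 2 to compound 3 (0.32 log units; beyond the scatter) and a 2.6-fold higher number from compound 1 to compound 3 (0.42 log units; beyond the scatter). Both steps lie beyond the scatter, whereas the exchange of one substituted phenyl for another stayed within it. No supporting data explain this shift.

On these data alone, whether the higher number goes with the five-membered ring or with its sulfur remains open. So does where furan-2-yl or pyridin-3-yl would fall.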